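The source may report more compounds than this note shows. Statements on the series, on what has been measured and on what is new or still open speak of the compounds shown alone.

In a functional assay on SW-620 cells (Homo sapiens) (a lower number here means a stronger inhibitor of growth, a higher number a weaker inhibitor of growth), compound 1 `O=S(=O)(/C=C/c1ccc(Br)cc1)Cc1ccc(Nc2ncnc3ccccc23)cc1` is reported only as a limit, > 100000 nM. Compound 2 `O=S(=O)(/C=C/c1ccc(F)cc1F)Cc1ccc(Nc2ncnc3ccccc23)cc1` gives 86000 nM. Compound 3 `O=S(=O)(/C=C/c1ccc(F)cc1Cl)Cc1ccc(Nc2ncnc3ccccc23)cc1` gives 100000 nM, so the two numbers stand level, with a 1.2-fold higher number from compound 2 to compound 3 (0.07 log units; within the scatter). Exchanging one substituted phenyl group for another gives an at least 1.1-fold lower number from compound 1 to compound 2 (0.06 log units; that floor lies within the scatter).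

Compound 4 `O=S(=O)(/C=C/c1ccc(F)cc1F)Cc1ccc(Nc2ncnc3cc(Cl)ccc23)cc1` keeps everything in compound 2 except for one change on the shared core: chloro in place of hydrogen on an aromatic carbon. Within the data shown here, no measured step touches this place, because every measured change lies on the substituted phenyl group. The closest guides are therefore indirect: the swap of chloro in place of fluoro, with a 1.2-fold higher number from compound 2 to compound 3 (0.07 log units; within the scatter), and the phenyl exchange, with an at least 1.1-fold lower number from compound 1 to compound 2 (0.06 log units; that floor lies within the scatter). Both are small, though neither says much about a new chloro on the core. No change beyond the scatter is therefore expected, and the uncertainty stays wide. The expected step is a 1.4-fold lower number from compound 2 to compound 4 (0.16 log units; within the scatter). For compound 4 the estimated value is 60000 nM, with an expected range from 15000 nM to 100000 nM.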

Compound 4, concentration for 50% growth inhibition: > 100000 nM
Compound 4 ended at the assay's limit (the forecaster's own chance of this, stated with the estimate: 25%); at least 1.6-fold (0.22 log units) between middle value and limit.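

Among these compounds, this is the first change on the shared core rather than on the substituted phenyl group: in this assay, chloro in place of hydrogen gives an at least 1.1-fold higher number from compound 2 to compound 4 (0.06 log units; that floor lies within the scatter) for this new position. On these data alone, the chloro at this carbon, meta to a fused ring and para to a fused ring, therefore brings no sign of stronger growth inhibition, while the true size of the step remains unknown. Compound 4 gives > 100000 nM, which is a limit and not a number, and it joins another compound there: the limit of > 100000 nM in this assay, at which 2 of the 4 values shown sit.

The compounds shown leave open whether a smaller or differently built group at this carbon, such as a methoxy group or an amine, would bring the number down. They also leave open how the same chloro would behave with other substituted phenyl groups.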